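The compounds below may be only part of what the source reports. "The series", "measured", "known", "first", "only" and "open" are said of these compounds alone.

For the measured compounds named here, compound 1 `CCS(=O)(=O)Nc1cc(-c2ccc3ncnc(Nc4ccc(OC(F)(F)F)cc4)c3c2)cnc1OC` gives 8240 nM in a functional assay on BT-549 cells (Homo sapiens) for cytotoxicity, read by sulforhodamine B assay, with a stated time of 72 h (a lower number here means a stronger inhibitor, a higher number a weaker inhibitor), the highest of the three numbers measured so far. Compound 2 `CCS(=O)(=O)Nc1cc(-c2ccc3ncnc(Nc4ccc(OC)cc4)c3c2)cnc1OC` gives 1880 nM in this assay, and compound 3 `CCS(=O)(=O)Nc1cc(-c2ccc3ncnc(Nc4ccc(C(=O)OC)c(OC)c4)c3c2)cnc1OC` gives 3760 nM. Compound 4 `CCS(=O)(=O)Nc1cc(-c2ccc3ncnc(Nc4ccc(F)nc4)c3c2)cnc1OC` has not yet been measured; it differs from compound 1 in that (6-fluoropyridin-3-yl in place of 4-(trifluoromethoxy)phenyl on a nitrogen on an aromatic ring). Going by the values given here, two measured steps bear on this change, since both also replace the 4-(trifluoromethoxy)phenyl group of compound 1 with a different ring on the same nitrogen: a 4.4-fold lower number from compound 1 to compound 2 (0.64 log units; beyond the scatter) and a 2.2-fold lower number from compound 1 to compound 3 (0.34 log units; beyond the scatter). Both moves away from the ring that carries the trifluoromethoxy group lowered the number beyond the scatter, though by different amounts. The step between those two replacements, a 2.0-fold higher number from compound 2 to compound 3 (0.30 log units; within the scatter), shows that they sit close to each other. The new ring in compound 4 again removes the trifluoromethoxy group, so a modest drop in the number is expected, a 2.4-fold lower number from compound 1 to compound 4 (0.37 log units; beyond the scatter), though the entering ring matches neither of the measured replacements exactly, which widens the range of what is expected. Compound 4 is therefore estimated at 3500 nM, with a range from 1200 nM to 10000 nM.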

Compound 4, half-maximal inhibitory concentration: 4780 nM
Estimate against measurement, compound 4: 1.4-fold (0.14 log units) below; low and high end bracket the measured number.
By their numbers in this assay, from the lowest: compounds 2, 3, 4 and 1 (each within the scatter of the next, the first and the last beyond it).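

In this assay, swapping 4-(trifluoromethoxy)phenyl for 6-fluoropyridin-3-yl on this nitrogen gives a 1.7-fold lower number from compound 1 to compound 4 (0.24 log units; within the scatter), so losing the trifluoromethoxy-bearing ring does not by itself move the number beyond the scatter, as it did with the two earlier replacements. Compound 4 cannot be told apart from the ester-bearing compound 3, at a 1.3-fold higher number from compound 3 to compound 4 (0.10 log units; within the scatter), yet it does separate from the methoxy compound, at a 2.5-fold higher number from compound 2 to compound 4 (0.41 log units; beyond the scatter), which shows that the choice between these two smaller rings on the nitrogen can register in this assay. No measurement of any other property accompanies these numbers, so nothing here explains the differences.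

The new ring differs from the 4-methoxyphenyl ring in two ways at once, a ring nitrogen and a fluorine in place of the methoxy group, and the compounds shown leave open which of these goes with the higher number; a plain 4-fluorophenyl group or a 6-methoxypyridin-3-yl group would separate them. Also open is how an amine or a carboxylic acid on this ring would read, since the rings shown carry only fluorine, ether and ester groups.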